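A few compounds are considered here, and "the series" means these few. Any claim that something is new, unique, unknown or untested is made for them only; others in the source may bear on it.

Three compounds that share one core differ only in the group that sits on a carbonyl carbon at the edge of the molecule. Compound 1 `CCn1c(-c2cnc(C)nc2)nc2c(O[C@H]3CCN(C(=O)C4CC4)C3)ncnc21` is measured in an ADME assay (Rattus norvegicus, strain Wistar Han) for pharmacokinetics (on this read-out higher numbers stand for wider distribution into tissues and lower numbers for narrower distribution), where compound 1 gives 0.7 L/kg. Compound 2 `CCn1c(-c2cnc(C)nc2)nc2c(N[C@H]3CCN(C(=O)C4CC(F)(F)C4)C3)ncnc21` gives 0.9 L/kg in this assay, and compound 3 `CCn1c(-c2cnc(C)nc2)nc2c(N[C@H]3CCN(C(=O)C4CCC4)C3)ncnc21` gives 0.5 L/kg. Compound 3 thus lies within the usual scatter of both compound 1 and compound 2, so the three numbers cannot be told apart.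

The new compound 4 `CCn1c(-c2cnc(C)nc2)nc2c(N[C@H]3CCN(C(=O)c4cocn4)C3)ncnc21` is the next step from compound 3. Its change is 1,3-oxazol-4-yl in place of cyclobutyl on a carbonyl carbon. Among the measured compounds shown here, the only measured step at the same position is a 1.8-fold lower number from compound 2 to compound 3 (0.26 log units; within the scatter), a swap of one ring for another on the carbonyl carbon that left the number essentially where it was. That swap kept ring size and ring type, whereas the present change brings in an aromatic ring with two hetero atoms, so the measured step is only a loose guide.

With nothing in the data pointing to a shift, compound 4 is expected to stay near compound 3, which means an expected step of a 1.2-fold higher number from compound 3 to compound 4 (0.08 log units; within the scatter). The estimate for compound 4 in this assay is 0.6 L/kg, with a range from 0.35 L/kg to 1.1 L/kg.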

Compound 4, volume of distribution: 0.6 L/kg
For compound 4 middle estimate and measured number coincide at the digits printed, and the stated range covers the measured number.
By their numbers in this assay, from the lowest: compounds 3, 4, 1 and 2 (each within the scatter of the next).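

In this assay, the position on the carbonyl carbon now proves tolerant of a change of ring type, not just of a change within one ring type: the step to 1,3-oxazol-4-yl gives a 1.2-fold higher number from compound 3 to compound 4 (0.08 log units; within the scatter) and, measured against the fluorinated ring, a 1.5-fold lower number from compound 2 to compound 4 (0.18 log units; within the scatter). The earlier step at this position, a 1.8-fold lower number from compound 2 to compound 3 (0.26 log units; within the scatter), only exchanged one non-aromatic four-membered ring for another, whereas this change brings in a five-membered aromatic ring with 2 hetero atoms and 2 hydrogen-bond acceptors, and the number still stays within the usual scatter. No measurement available here explains why the number holds steady across these rings.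

From the compounds shown here alone, whether a group of another kind on this carbonyl carbon, such as a ring carrying an amine, a carboxylic acid or a longer alkyl chain, would move the number beyond the scatter remains open. Compound 1 differs from the other compounds in more than one place, so the atom linking its side ring to the shared core cannot be judged on its own.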